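The source may report more compounds than this note shows. Statements on the series, on what has been measured and on what is new or still open speak of the compounds shown alone.

Measured so far:
compound 1, `CC(C)=CCC1Cc2c(O)cc(=O)n(CCCO)c2CC1(C)C`, gives 0% in a functional assay on PANC-1 cells (Homo sapiens) for inhibition, read by MTT assay, with a stated time of 24 h, tested at 10 uM; on this read-out higher numbers stand for more inhibition at the one concentration tested (going by the name of the read-out) and lower numbers for less inhibition
compound 2, `CC(C)=CCC1Cc2c(OCCCOc3ccc(Cl)cc3)cc(=O)n(CCCO)c2CC1(C)C`, gives 0% in this assay
compound 3, `COc1ccccc1NC(=O)Oc1cc(=O)n(CCCO)c2c1CC(CC=C(C)C)C(C)(C)C2`, gives 0% in this assay

Compound 1 stands level with compounds 2 and 3 on these numbers: the step of no change at the digits printed from compound 1 to compound 2 (within the scatter) and the step of no change at the digits printed from compound 1 to compound 3 (within the scatter) both lie within the scatter, and so does the step of no change at the digits printed from compound 2 to compound 3 (within the scatter). All three compounds share the same core and differ only in what sits on one oxygen of the aromatic ring.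

Compound 4, `CC(C)=CCC1Cc2c(OC(=O)Nc3ccccc3F)cc(=O)n(CCCO)c2CC1(C)C`, follows the same pattern. Its difference from compound 1 is (2-fluorophenyl)carbamoyl in place of hydrogen on an oxygen on an aromatic ring. For the measured compounds named here, the closest precedent is the step from compound 1 to compound 3, which placed a carbamoyl group on the same oxygen and left the read-out unchanged within the scatter; the step from compound 1 to compound 2, a different substituent on that oxygen, also left it unchanged. Going by the values given here, nothing among the measured compounds suggests that a carbamoyl carrying a fluorine in place of a methoxy group on its phenyl ring should behave differently in this assay.

Compound 4 is therefore expected to give about 0% in this assay, with a likely range from 0% to 10%. The expected step of no change at the digits printed from compound 1 to compound 4 (within the scatter) is thus estimated to be none beyond the scatter.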

Compound 4, a percentage reported as inhibition, at one concentration (the size of the read-out at that concentration, not a potency): 0%
Compound 4: middle estimate and measured number agree at the digits printed, within the range that was stated.
By their numbers in this assay, from the lowest: compounds 1, 2, 3 and 4 (each within the scatter of the next).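

In this assay, a second arylcarbamoyl on the oxygen on an aromatic ring leaves the picture as it was, with no change at the digits printed from compound 1 to compound 4 (within the scatter). For the compounds shown here, what the earlier compounds could not show is a change made within the carbamoyl series itself: fluoro in place of methoxy on an aromatic carbon of its phenyl ring gives no change at the digits printed from compound 3 to compound 4 (within the scatter), so this one exchange on that ring does not lift the read-out from the level of the other compounds. The comparison between the two kinds of group on this oxygen extends to the new compound as well, with (2-fluorophenyl)carbamoyl in place of 3-(4-chlorophenoxy)propyl giving no change at the digits printed from compound 2 to compound 4 (within the scatter), so all four compounds now sit level at the one concentration tested and cannot be ranked.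

The compounds shown leave open whether any group on this oxygen would give a read-out above that level, such as a carboxylic acid, an amine at the end of a longer chain, or a carbamoyl with a nitrile on its phenyl ring. Nothing available explains why these changes leave the read-out where it stands.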